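The source may hold more compounds than are shown below. What is called first, only, known or untested is meant among the compounds shown, and "the series" means these compounds.

Measured compounds:
Compound 1 `O=C(c1ccc([N+](=O)[O-])cc1)N1CCC(n2cncc2-c2ccc(OS(=O)(=O)c3cccc4cnccc34)cc2)CC1` gives 1.49 nM.
Compound 2 `CN(C)c1ccc(C(=O)N2CCC(n3cncc3-c3ccc(OS(=O)(=O)c4cccc5cnccc45)cc3)CC2)cc1` gives 0.11 nM.
Compound 3 `O=C(c1ccc([N+](=O)[O-])cc1)N1CCC(c2nc3cc(OS(=O)(=O)c4cccc5cnccc45)ccc3[nH]2)CC1` gives 13 nM.

All three were tested in an assay on HEK293 cells for antagonist activity at P2X purinoceptor 7 (Homo sapiens), read by fluorescence, with a stated time of 2 h; on this read-out higher numbers stand for weaker inhibition and lower numbers for stronger inhibition. Compounds 1 and 2 share one core and differ in a single place: dimethylamino in place of nitro on an aromatic carbon. That change gave a 14-fold lower number from compound 1 to compound 2 (1.13 log units; beyond the scatter), so compound 2 ended with the lowest number of the three. Compound 3 is built on a different core, and how the two cores differ is not broken down here; what the values show is that compound 3 gives the highest number of the three, with compound 1 nearest and compound 2 furthest away.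

Compound 4 `CN(C)c1ccc(C(=O)N2CCC(c3nc4cc(OS(=O)(=O)c5cccc6cnccc56)ccc4[nH]3)CC2)cc1` has not yet been measured in this assay. It stands to compound 3 exactly as compound 2 stands to compound 1: dimethylamino in place of nitro on an aromatic carbon. The place of the change is described in the same words for both pairs, so this is the same change made on the second core.

The expectation for compound 4 in this assay is a step of roughly an 8.7-fold lower number from compound 3 to compound 4 (0.94 log units; beyond the scatter), that is, a clearly lower number than compound 3. This rests on the fact that the same change, made once before, gave a 14-fold lower number from compound 1 to compound 2 (1.13 log units; beyond the scatter), and there is no measured case in which it did otherwise. Within the data shown here, since only one earlier example exists, the expected step is kept somewhat smaller than that one. Compound 4 is therefore estimated at 1.5 nM, with a likely range from 0.4 nM to 5 nM.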

Compound 4, half-maximal inhibitory concentration: 41 nM
For compound 4 the middle estimate is 27-fold (1.44 log units) below the measured one, outside the stated range (above it).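

The new step, in this assay, replaces nitro with dimethylamino on the second core and gives a 3.2-fold higher number from compound 3 to compound 4 (0.50 log units; beyond the scatter), so the change that lowered the number on the first core raises it here, and the two results clearly disagree: the same change on two cores in this assay, a 14-fold lower number (1.13 log units; beyond the scatter) from compound 1 to compound 2 and a 3.2-fold higher number (0.50 log units; beyond the scatter) from compound 3 to compound 4, 43-fold (1.63 log units) apart, beyond the scatter of two such steps

This shows that, in this series, the effect of this change cannot simply be carried from one core to the other, since even its direction was different on the two cores. It does not show which feature of the cores lies behind the difference, nor what the same change would do on any further core.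

As far as these compounds go, each core is represented here by only nitro and dimethylamino in this place, so it remains open how a group such as methoxy, a primary amine or a carboxylic acid would behave there on either core. From the compounds shown here alone, with a single pair on each core, it also remains open whether the opposite directions would extend to other groups or belong to this one pair alone.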